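Working notes on cytotoxicity across compounds 1 to 4

The compounds below may be only part of what the source reports. "The series", "measured", "known", "first", "only" and "open" are said of these compounds alone.

Measured so far:
compound 1 `O=[N+]([O-])c1ccc2[nH]cc(C(c3ccccc3)c3cc4cc(Cl)ccc4o3)c2c1` gives > 100000 nM in a functional assay on SiHa cells (Homo sapiens) for cytotoxicity (on this read-out higher numbers stand for weaker inhibition and lower numbers for stronger inhibition), a limit of the assay rather than a number.
compound 2 `COc1ccc2oc(C(c3ccccc3)c3c(C)[nH]c4ccccc34)cc2c1` gives > 100000 nM in this assay, likewise a limit.
compound 3 `CC(C)(C)c1cc(C(C)(C)C)c2oc(C(c3ccccc3)c3c[nH]c4ccccc34)cc2c1` gives 61600 nM in this assay.

Among the measured compounds shown here, compound 3 is thus the only member with a measured number; the two others sit at the limit of > 100000 nM in this assay, at which 2 of the 3 values shown sit. Compound 4 `Cc1[nH]c2ccccc2c1C(c1ccccc1)c1cc2cc(C(C)(C)C)cc(C(C)(C)C)c2o1` is not yet measured and differs from compound 3 by methyl in place of hydrogen on an aromatic carbon. Compound 2 also carries the 2-methyl indole, and in this assay compound 2 returns only a limit. For the measured compounds named here, no step between measured compounds exists, so the expectation rests on that alone. For compound 4 the expected step is a 1.5-fold higher number from compound 3 to compound 4 (0.16 log units; within the scatter), toward weaker inhibition. Compound 4 is estimated at 90000 nM, between 30000 nM and 300000 nM, with a fair chance of a limit only.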

Compound 4, half-maximal inhibitory concentration: 72000 nM
Beside the measured number, compound 4's estimate is 1.3-fold (0.10 log units) above it, and the stated range covers the measured number.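

Methyl in place of hydrogen, on the aromatic carbon next to the ring nitrogen, gives the first readable step in the series: in this assay the change from 1H-indol-3-yl to 2-methyl-1H-indol-3-yl is a 1.2-fold higher number from compound 3 to compound 4 (0.07 log units; within the scatter). On this core, the two groups at this position cannot be told apart. No data shown bear on the reason for this result.

Going by these compounds, whether an ethyl chain, an amine or a carboxylic acid at this position would separate from hydrogen remains open. On these data alone, whether methyl behaves alike on other cores also remains open.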